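The source may report more compounds than this note shows. Statements on the series, on what has been measured and on what is new or still open speak of the compounds shown alone.

Measured in an ADME assay on LLC-MK2 cells (Macaca mulatta) for cytotoxicity, read by MTT assay, with a stated time of 48 h; a lower number here means that less compound is tolerated, a higher number that more compound is tolerated:
Compound 1 `COc1ccc(/C=C/C(=O)/C(C)=C/c2ccc(OC)cc2)cc1`: 75000 nM
Compound 2 `COc1ccc(/C=C(\C)C(=O)/C=C/c2ccc(N(C)C)cc2)cc1`: 411000 nM

Of these two, compound 2 stands highest at 411000 nM. Compound 3 `C/C(=C\c1ccc(N(C)C)cc1)C(=O)/C=C/c1ccc(N(C)C)cc1` has not yet been measured. It exchanges the methoxy that remains in compound 2: dimethylamino in place of methoxy on an aromatic carbon, para to a large group. For the measured compounds named here, the only measured step that bears on this is a 5.5-fold higher number from compound 1 to compound 2 (0.74 log units; beyond the scatter), a modest one, with the same exchange made at the other methoxy. One step is thin ground, so a rise of similar or somewhat smaller size is expected in this assay. The expected step is a 2.9-fold higher number from compound 2 to compound 3 (0.47 log units; beyond the scatter). For compound 3 the estimated value is 1200000 nM, with an expected range of 300000 nM to 3000000 nM.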

Compound 3, half-maximal cytotoxic concentration: 314000 nM
Beside the measured number, compound 3's estimate is 3.8-fold (0.58 log units) above it; the measured number falls inside the stated range.
By their numbers in this assay, from the lowest: compound 1; then compounds 3 and 2 (each within the scatter of the next).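

In this assay, exchanging the remaining methoxy for dimethylamino, on the aromatic carbon para to a large group, gives a 1.3-fold lower number from compound 2 to compound 3 (0.12 log units; within the scatter). The same kind of exchange at the other methoxy gave a 5.5-fold higher number from compound 1 to compound 2 (0.74 log units; beyond the scatter), so its effect does not carry over to this position. With dimethylamino in both places, the number stays within the scatter of the compound that keeps one methoxy.

Open, going by these compounds, is how a primary amine, a hydroxyl or a morpholine would read at this position. No measurement here gives a reason why the two steps differ.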